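The source may report more compounds than this note shows. Statements on the series, on what has been measured and on what is new or still open speak of the compounds shown alone.

Working notes on a small thiocarbamate series tested in an ADME assay on MT4 cells (Homo sapiens) for cytotoxicity, read by MTT assay; on this read-out lower numbers stand for higher toxicity in this test and higher numbers for lower toxicity in this test.

Compound 1 `O=[N+]([O-])c1ccc(NC(=S)OCCc2ccccn2)cc1` pairs a nitro group with a (pyridin-2-yl)methyl-bearing chain. In this assay compound 1 reaches only a limit of the test, > 100000 nM. Compound 2 `COc1ccc(NC(=S)OCCc2ccccn2)cc1` differs from compound 1 by methoxy in place of nitro on an aromatic carbon. In this assay compound 2 gives 48000 nM. The measured step is an at least 2.0-fold lower number from compound 1 to compound 2 (0.31 log units; beyond the scatter); only its lower bound is readable, since compound 1 sits at a limit.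

Compound 3 `O=[N+]([O-])c1ccc(NC(=S)OCCc2ccccc2)cc1` differs from compound 1 in the core: phenyl in place of pyridin-2-yl on a saturated chain carbon, two bonds along the chain from an oxygen on an unsaturated carbon. In this assay compound 3 again reaches only a limit, > 100000 nM. The step that the two limits leave unreadable from compound 1 to compound 3 cannot be sized because the limit of > 100000 nM in this assay, at which 2 of the 3 values shown sit, caps both ends of it.

Compound 4 `COc1ccc(NC(=S)OCCc2ccccc2)cc1` has not yet been measured in this assay. From compound 3 it differs by methoxy in place of nitro on an aromatic carbon, the same change as from compound 1 to compound 2, at the same place, now on the core of compound 3. The expectation for compound 4 rests on compound 2 giving 48000 nM and on the measured step of an at least 2.0-fold lower number from compound 1 to compound 2 (0.31 log units; beyond the scatter). For compound 4 the expected step in this assay is an at least 2.0-fold lower number from compound 3 to compound 4 (0.30 log units; that floor lies within the scatter), read as a lower bound only, since compound 3 sits at a limit. For compound 4 the estimate in this assay is 50000 nM, expected to fall between 15000 nM and 150000 nM. On these data alone, whether a number or again a limit is returned remains open until compound 4 is measured.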

Compound 4, half-maximal cytotoxic concentration: 36000 nM
The estimate for compound 4 lay 1.4-fold (0.14 log units) above the measured number; measured number inside the range.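

In this assay, methoxy in place of nitro gives an at least 2.7-fold lower number from compound 3 to compound 4 (0.44 log units; beyond the scatter), so the lower number seen on the core of compound 1 recurs on the core of compound 3, with both steps printed as beyond the scatter: the same change on two cores in this assay, an at least 2.0-fold lower number (0.31 log units; beyond the scatter) from compound 1 to compound 2 and an at least 2.7-fold lower number (0.44 log units; beyond the scatter) from compound 3 to compound 4; the limit leaves it open whether they differ. Neither step can be given a full size, and the phenyl-for-pyridin-2-yl step between the two nitro compounds cannot be read, as compound 1 and compound 3 both stand at a limit of the test: the limit of > 100000 nM in this assay, at which 2 of the 4 values shown sit. On the methoxy side, the same core change gives a 1.3-fold lower number from compound 2 to compound 4 (0.12 log units; within the scatter), so the two methoxy compounds are not told apart here, but two cores are a narrow basis and show only that the direction of the methoxy change is shared by this pair of cores, not that its size carries over.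

Still open, on these data alone, is whether the same behaviour holds for other groups on that aromatic carbon, such as an amine or a carboxylic acid, or with a longer chain on the oxygen. Also open, as far as these compounds go, are the actual numbers for compound 1 and compound 3, and with them whether the step differs between the two cores.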